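Swapping the spiro amine for a fused bicycle

The compounds below may be only part of what the source reports. "The series", "measured", "known", "first", "only" and "open" are said of these compounds alone.

Measured compounds:
compound 1 `COc1ccc2[nH]c(C(=O)N3CC(=O)N(Cc4ccccc4)[C@@H](CN4CCC5(CC4)CC5)C3)cc2c1` gives 17100 nM
compound 2 `COc1ccc2[nH]c(C(=O)N3CC(=O)N(Cc4ccoc4)[C@@H](Cc4ccccc4)C3)cc2c1` gives > 10000 nM
compound 3 `COc1ccc2[nH]c(C(=O)N3CC(=O)N(Cc4c[nH]c5ccccc45)[C@@H](Cc4ccccc4)C3)cc2c1` gives 7200 nM

In an ADME assay on Vero cells (Chlorocebus sabaeus) for cytotoxicity, with a stated time of 7 days (a higher number here means that more compound is tolerated, a lower number that less compound is tolerated), compound 1 holds the highest of the two numbers, with compound 3 the nearest, beyond the scatter below it. Compound 2 reports only a limit, the one described by the limit of > 10000 nM in this assay, at which 1 of the 3 values shown sits. Compound 4 `COc1ccc2[nH]c(C(=O)N3CC(=O)N(Cc4ccccc4)[C@@H](CN4CC5CCCCC5C4)C3)cc2c1` differs from compound 1 by a group of 9 heavy atoms (8 carbon, 1 nitrogen; one five-membered non-aromatic ring with 1 hetero atom, one six-membered non-aromatic ring of carbon only) in place of a group of 8 heavy atoms (7 carbon, 1 nitrogen; one three-membered non-aromatic ring of carbon only, one six-membered non-aromatic ring with 1 hetero atom), on a saturated chain carbon bound to a saturated ring carbon. Within the data shown here, the only measured step, an at least 1.3-fold lower number from compound 2 to compound 3 (0.14 log units; that floor lies within the scatter), changes a different place and stays within the scatter, so it offers no guide of its own to this change. No step beyond the scatter is therefore expected. Compound 4 is estimated at 15000 nM, within 6000 nM to 40000 nM, which is expected to mean a 1.1-fold lower number from compound 1 to compound 4 (0.06 log units; within the scatter).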

Compound 4, half-maximal cytotoxic concentration: 8200 nM
For compound 4 the middle estimate is 1.8-fold (0.26 log units) above the measured one, within the range that was stated.
By their numbers in this assay, from the lowest: compounds 3 and 4 (each within the scatter of the next); then compound 1.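

In this assay, among these compounds, the earlier compounds gave no step at this place, and the change of ring-bearing amine on a saturated chain carbon bound to a saturated ring carbon now gives one: a 2.1-fold lower number from compound 1 to compound 4 (0.32 log units; beyond the scatter). Even so modest a step shows that the number responds to this group, though the two groups carry the same count of hydrogen-bond donors and acceptors. No measurement shown bears on why.

As far as these compounds go, whether a morpholine or a diethylamino group in this place would fall nearer compound 1 or compound 4 remains open.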